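This account rests on a few compounds, and the source may have more. Where it says the series, first, only, none or still open, it means among the compounds named here.

Measured compounds:
- compound 1, `O=C(NCc1ccccc1)N(Cc1ccccn1)n1cnnc1`: > 50000 nM
- compound 2, `CC1CCC(NC(=O)N(Cc2ccccn2)n2cnnc2)CC1`: 33200 nM

In a functional assay on MDA-MB-231 cells (Homo sapiens) for cytotoxicity, read by MTT assay, with a stated time of 48 h (a higher number here means a weaker inhibitor, a lower number a stronger inhibitor), compound 1 reaches only a limit of the assay, > 50000 nM. Within the data shown here, compound 2 gives 33200 nM in this assay, the only real number among the two values shown. Among the measured compounds shown here, the one measured step, an at least 1.5-fold lower number from compound 1 to compound 2 (0.17 log units; that floor lies within the scatter), puts 4-methylcyclohexyl in place of benzyl on an amide-type nitrogen, and its size is bounded by the limit of > 50000 nM in this assay, at which 1 of the 2 values shown sits, rather than by a second number.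

Compound 3, `O=C(NC1CCCCC1)N(Cc1ccccn1)n1cnnc1`, differs from compound 2 by hydrogen in place of methyl on a saturated ring carbon, which is hydrogen in place of methyl on a saturated ring carbon. For the measured compounds named here, no measured step removes a methyl from a saturated ring; the only step known replaces the whole ring substituent and is itself capped by a limit. There is thus no measured basis for a change beyond the scatter in this assay.

Compound 3 is therefore expected to give about 40000 nM, within a range from 15000 nM to 100000 nM. That estimate means an expected step of a 1.2-fold higher number from compound 2 to compound 3 (0.08 log units; within the scatter), lying within the scatter, with a real chance that only a limit is reported.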

Compound 3, half-maximal inhibitory concentration: 44100 nM
Estimate against measurement, compound 3: 1.1-fold (0.04 log units) below, within the range that was stated.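

Removing the methyl from the saturated ring carbon, three ring bonds from the ring atom that bears a large group, gives a 1.3-fold higher number from compound 2 to compound 3 (0.12 log units; within the scatter) in this assay and so does not separate the two compounds. Among these compounds, this is the first step read between two real numbers rather than against a limit, and it shows that the methyl in 4-methylcyclohexyl makes no difference beyond the scatter here. Cyclohexyl in place of benzyl on an amide-type nitrogen gives an at least 1.1-fold lower number from compound 1 to compound 3 (0.05 log units; that floor lies within the scatter), but this is only a floor, and the true size of the step stays unknown because compound 1 reaches a limit rather than a number: the limit of > 50000 nM in this assay, at which 1 of the 3 values shown sits.

Whether an amine, a carboxylic acid or a longer chain such as propyl on that same ring carbon would shift the number beyond the scatter remains open, since methyl and hydrogen are the only two groups shown there. Also open, as far as these compounds go, is whether any group on the amide-type nitrogen, such as a longer alkyl chain, would move the number well away from the values shown for compound 2 and compound 3.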